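The source may report more compounds than this note shows. Statements on the series, on what has been measured and on what is new or still open speak of the compounds shown alone.

Measured compounds in a functional assay on IGROV-1 cells (Homo sapiens) for inhibition, read by sulforhodamine B assay, with a stated time of 48 h; a higher number here means a weaker inhibitor of growth, a lower number a stronger inhibitor of growth:
- compound 1 `CN1CCN(CCCOc2cccc3nc(Nc4ccc(Cl)c(C(F)(F)F)c4)ccc23)CC1` gives 1850 nM
- compound 2 `CN1CCN(CCCOc2cccc3nc(Nc4ccc(Cl)c(F)c4)ccc23)CC1` gives 1950 nM
- compound 3 `CN1CCN(CCCOc2cccc3nc(Nc4ccc(F)c(F)c4)ccc23)CC1` gives 5550 nM

Compound 3 has the highest number of the three in this assay. The nearest is compound 2, a 2.8-fold higher number from compound 2 to compound 3 (0.45 log units; beyond the scatter); the furthest is compound 1, a 3.0-fold higher number from compound 1 to compound 3 (0.48 log units; beyond the scatter). Between compound 1 and compound 2 the change is a 1.1-fold higher number from compound 1 to compound 2 (0.02 log units; within the scatter).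

Compound 4 `CN1CCN(CCCOc2cccc3nc(Nc4cccc(Cl)c4)ccc23)CC1` differs from compound 3 in one place: 3-chlorophenyl in place of 3,4-difluorophenyl on a nitrogen on an aromatic ring. Among the compounds with values here, two measured steps bear on this change. The step from compound 2 to compound 3 is the closest comparison, since it is a chloro-to-fluoro swap on the aryl ring, and it raised the number beyond the scatter; reading it backwards, putting a chlorine back on the ring in place of a fluorine should lower the number by a comparable margin. The step from compound 1 to compound 3 points the same way. Within the data shown here, neither step, however, removes a halogen altogether, and compound 4 carries only one ring substituent, so the return toward the numbers of compound 1 and compound 2 may be incomplete.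

Compound 4 is therefore expected to fall below compound 3 in this assay, with an estimated step of a 1.9-fold lower number from compound 3 to compound 4 (0.27 log units; within the scatter). The estimate for compound 4 is 3000 nM, with a range from 1200 nM to 7500 nM.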

Compound 4, concentration for 50% growth inhibition: 2230 nM
Estimate against measurement, compound 4: 1.3-fold (0.13 log units) above, within the range that was stated.
By their numbers in this assay, from the lowest: compounds 1, 2 and 4 (each within the scatter of the next); then compound 3.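

Moving from 3,4-difluorophenyl to 3-chlorophenyl in this assay gives a 2.5-fold lower number from compound 3 to compound 4 (0.40 log units; beyond the scatter) at this position on the nitrogen, so a single chlorine on the ring, with no fluorine, is enough to leave the range of compound 3. Within the data shown here, the comparisons with the two disubstituted chloro rings, a 1.1-fold higher number from compound 2 to compound 4 (0.06 log units; within the scatter) and a 1.2-fold higher number from compound 1 to compound 4 (0.08 log units; within the scatter) are both within the scatter, so in this set a second ring substituent adds nothing that can be read, whether it is fluoro or trifluoromethyl, and the chlorine need not be the one in the 4-chloro groups. Among the four compounds the three that carry chlorine form one group and compound 3, the only one without it, stands apart, with no compound going against this grouping, though four compounds make a narrow basis. Nothing shown gives a reason for this grouping.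

Still open, from the compounds shown here alone, is whether chlorine itself matters or whether the 3,4-difluorophenyl group is a particular case, a question that 3-fluorophenyl, 4-chlorophenyl or unsubstituted phenyl on the same nitrogen would address. Also open, going by these compounds, is how far the ring tolerates other kinds of group, such as a methoxy, a nitrile or a carboxylic acid in place of the chlorine.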